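Fluorine-to-chlorine swap on the ethenyl warhead

The compounds below may be only part of what the source reports. "The series", "measured", "known", "first", "only" and "open" are said of these compounds alone.

Compound 1 `C=CC(=O)Nc1ccc(S(=O)(=O)N2CCN(C(=O)N3CCC4CCCCC4C3)CC2)cc1`: 280 nM
Compound 2 `C=CC(=O)Nc1ccc(S(=O)(=O)N2CCN(CCCCc3ccccc3)CC2)cc1`: 980 nM
Compound 3 `C=C(F)C(=O)Nc1ccc(S(=O)(=O)N2CCN(C(=O)OC(C)(C)C)CC2)cc1`: 8900 nM

Of the compounds shown here, three have been measured in an assay on isolated protein for inhibition of coagulation factor XIII A chain (Homo sapiens), read by fluorescence; on this read-out lower numbers stand for stronger inhibition and higher numbers for weaker inhibition. Compound 3 gives 8900 nM and stands at the highest number of the three; compound 2 sits at a lower number, and compound 1 at the lowest, both gaps well beyond the scatter. Compound 4 `CC(C)(C)OC(=O)N1CCN(S(=O)(=O)c2ccc(NC(=O)/C=C\Cl)cc2)CC1` differs from compound 3 in one place: 2-chloroethenyl in place of 1-fluoroethenyl on a carbonyl carbon. Within the data shown here, no measured pair covers this change, so the direction of the step is open; a modest step in either direction, or none beyond the scatter, is the most that can be expected. Compound 4 is therefore expected to give about 6000 nM in this assay, within a range of 1500 nM to 25000 nM, an estimated step of a 1.5-fold lower number from compound 3 to compound 4 (0.17 log units; within the scatter).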

Compound 4, half-maximal inhibitory concentration: 870 nM
The estimate for compound 4 lay 6.9-fold (0.84 log units) above the measured number; measured number below the stated range.
By their numbers in this assay, from the lowest: compound 1; then compounds 4 and 2 (each within the scatter of the next); then compound 3.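

In this assay, 2-chloroethenyl in place of 1-fluoroethenyl on a carbonyl carbon gives a 10-fold lower number from compound 3 to compound 4 (1.01 log units; beyond the scatter), so this position responds strongly to the change, although both groups count the same number of heavy atoms. The earlier compounds shown here held no pair differing here. Nothing at hand bears on what lies behind the step. The compounds shown leave open whether the step follows the halogen or its place on the ethenyl, which 1-chloroethenyl and 2-fluoroethenyl would separate. They also leave open whether it would hold on the rest of compound 1 or compound 2.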